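From 2-nitrophenyl to 3-methylphenyl on an aromatic nitrogen

The compounds below may be only part of what the source reports. "The series", "measured", "known", "first", "only" and "open" are said of these compounds alone.

Compound 1 `C/C(=C\CC/C(C)=C/CC[C@@H]1[C@@]2(C)CCC(=O)C(C)(C)[C@H]2CC[C@@]1(C)O)CC/C=C(\C)C(=O)OCc1cn(-c2ccccc2[N+](=O)[O-])nn1`: > 150000 nM (a limit)
Compound 2 `C/C(=C\CC/C(C)=C/CC[C@@H]1[C@@]2(C)CCC(=O)C(C)(C)[C@H]2CC[C@@]1(C)O)CC/C=C(\C)C(=O)OCc1cn(C[C@@H]2O[C@H](n3ccc(=O)[nH]c3=O)C[C@H]2O)nn1`: 33100 nM

In a functional assay on DU-145 cells (Homo sapiens) for antiproliferative activity, read by MTT assay, with a stated time of 48 h (a lower number here means a stronger inhibitor, a higher number a weaker inhibitor), compound 1 gives > 150000 nM as a limit of the assay and not as a number. Compound 1 stands at the limit of > 150000 nM in this assay, at which 1 of the 2 values shown sits, among the measured compounds. Compound 2 gives 33100 nM in this assay as a measured number. Compound 3 `C/C(=C\CC/C(C)=C/CC[C@@H]1[C@@]2(C)CCC(=O)C(C)(C)[C@H]2CC[C@@]1(C)O)CC/C=C(\C)C(=O)OCc1cn(-c2cccc(C)c2)nn1` carries 3-methylphenyl in place of 2-nitrophenyl on an aromatic nitrogen. Within the data shown here, no measured step shows what this swap does, so the estimated at least 1.2-fold lower number from compound 1 to compound 3 (0.09 log units; that floor lies within the scatter) is expected to stay within the scatter. For compound 3 the expected value in this assay is 120000 nM with 45000 nM and 300000 nM as the ends of its range.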

Compound 3, half-maximal inhibitory concentration: 137000 nM
Beside the measured number, compound 3's estimate is 1.1-fold (0.06 log units) below it; low and high end bracket the measured number.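

In this assay, 3-methylphenyl in place of 2-nitrophenyl on the aromatic nitrogen gives an at least 1.0-fold lower number from compound 1 to compound 3 (0.03 log units; that floor lies within the scatter). This change yields a measured number for compound 3, but no shift that can be told from the scatter. The value for compound 1 remains a limit and not a number: the limit of > 150000 nM in this assay, at which 1 of the 3 values shown sits.

Because the swap alters both the group and its place on the phenyl ring, the two effects cannot be separated here. Going by these compounds, it remains open whether an amine or a carboxylic acid on that ring would lower the number beyond the scatter.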